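Replacing the Methylpiperazine Group of Compound 1 with a Triazole

The compounds below may be only part of what the source reports. "The series", "measured", "known", "first", "only" and "open" are said of these compounds alone.

Measured compounds:
Compound 1, `CN1CCN(c2ccc(C3=NN(S(=O)(=O)c4ccc(C(F)(F)F)cc4)C(c4ccc(N(C)C)cc4)C3)cc2)CC1`: 12.1%
Compound 2, `CN1CCN(c2ccc(C3=NN(S(=O)(=O)c4ccc(OC(F)(F)F)cc4)C(c4ccc(N(C)C)cc4)C3)cc2)CC1`: 10.6%

Both were tested in a functional assay on MDA-MB-231 cells (Homo sapiens) for inhibition, read by sulforhodamine B assay, tested at 10 uM; a higher number here means more inhibition at the concentration tested (going by the name of the read-out), a lower number less inhibition. Compound 1 gives 12.1%, the larger of the two numbers shown, while compound 2 gives 10.6%; the step of a number 1.5 percentage points lower from compound 1 to compound 2 (within the scatter) lies within the scatter, so the two cannot be told apart. Compound 3, `CN(C)c1ccc(C2CC(c3ccc(-n4cncn4)cc3)=NN2S(=O)(=O)c2ccc(C(F)(F)F)cc2)cc1`, has not been measured. It differs from compound 1 in one place: 1H-1,2,4-triazol-1-yl in place of 4-methylpiperazin-1-yl on an aromatic carbon. Going by the values given here, the only measured step concerns the trifluoromethyl and trifluoromethoxy groups on another ring and was within the scatter; no measured step touches the 4-methylpiperazin-1-yl group. There is thus no basis for expecting a step beyond the scatter in either direction. Compound 3 is therefore estimated at 12%, with a range from 0% to 30%. This corresponds to an expected step of a number 0.1 percentage points lower from compound 1 to compound 3 (within the scatter).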

Compound 3, a percentage reported as inhibition, at one concentration (the size of the read-out at that concentration, not a potency): 15.3%
The estimate for compound 3 lay 3.3 percentage points below the measured number; low and high end bracket the measured number.
By their numbers in this assay, from the lowest: compounds 2, 1 and 3 (each within the scatter of the next).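

In this assay, going by these compounds alone, this is the first change at the aromatic carbon para to a large group, and replacing 4-methylpiperazin-1-yl with 1H-1,2,4-triazol-1-yl gives a number 3.2 percentage points higher from compound 1 to compound 3 (within the scatter), so the two compounds cannot be told apart. A six-membered non-aromatic ring is thus exchanged for a five-membered aromatic ring with a smaller heavy-atom count and no change that can be read, and compound 3 stays at 15.3%. No measurement at hand bears on the reason for this result.

Going by these compounds, it remains open whether a morpholine ring, a primary amine or a carboxylic acid at this position would move the number beyond the scatter. On these data alone, it is also open whether the triazole would behave the same way with trifluoromethoxy in place of trifluoromethyl on the other ring.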